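Removing One Methyl from Compound 2

This account rests on a few compounds, and the source may have more. Where it says the series, first, only, none or still open, it means among the compounds named here.

In an ADME assay on MT4 cells (Homo sapiens) for cytotoxicity, read by MTT assay, with a stated time of 4 days (a higher number here means that more compound is tolerated, a lower number that less compound is tolerated), compound 1 (`O=C(c1cc(Cl)cc(Cl)c1)c1cc(Cl)ccc1OCCn1ccc(=O)[nH]c1=O`) gives > 284000 nM, which is a limit. From the compounds shown here alone, compound 2 (`Cc1cc(C)cc(C(=O)c2cc(Cl)ccc2OCCn2ccc(=O)[nH]c2=O)c1`) gives > 313000 nM, also a limit, so its true value stays unknown. Compound 3 (`Cc1cccc(C(=O)c2cc(Cl)ccc2OCCn2ccc(=O)[nH]c2=O)c1`) turns 3,5-dimethylphenyl into 3-methylphenyl, with hydrogen in place of methyl on an aromatic carbon. Among the compounds with values here, the only measured step that bears on this, a step that the two limits leave unreadable from compound 1 to compound 2, offers no size to carry over, so no change beyond the usual scatter is expected. The estimated change is a step that the limit leaves unreadable from compound 2 to compound 3. For compound 3 the expected value is 325000 nM, with an estimated range from 150000 nM to 450000 nM.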

Compound 3, half-maximal cytotoxic concentration: > 325000 nM
Compound 3 ended at the assay's limit; the forecaster's own chance of this, stated with the estimate: 85%; the middle value lies on the limit itself.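

Within the data shown here, compound 1, compound 2 and compound 3 each give only a limit, so no step among them can be read. The compounds shown leave open where each true value lies and whether these changes shift it at all.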